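Replacing the amide group of compound 3 with phenyl

This account rests on a few compounds, and the source may have more. Where it says the series, first, only, none or still open, it means among the compounds named here.

In a functional assay on HEY cells (Homo sapiens) for cytotoxicity, read by MTT assay, with a stated time of 72 h (a lower number here means a stronger inhibitor, a higher number a weaker inhibitor), compound 1 (`COc1cccc(CNC(=O)c2nc(Br)c3cccnc3c2N[C@H]2CC[C@H](N)CC2)c1`) gives 7000 nM. Compound 2 (`C[C@H](NC(=O)c1nc(Br)c2cccnc2c1N[C@H]1CC[C@H](N)CC1)c1ccc(F)cc1`) reads > 10000 nM, which is a limit of the assay. Compound 3 (`N[C@H]1CC[C@H](Nc2c(C(=O)NCc3ccccn3)nc(Br)c3cccnc23)CC1`) reads > 20000 nM, also a limit rather than a number. Compound 4 (`N[C@H]1CC[C@H](Nc2c(C(=O)Nc3ccccc3)nc(Br)c3cccnc23)CC1`) has phenyl in place of (pyridin-2-yl)methyl on an amide-type nitrogen. Two measured changes at this nitrogen bear on it: an at least 1.4-fold higher number from compound 1 to compound 2 (0.15 log units; that floor lies within the scatter), and an at least 2.8-fold higher number from compound 1 to compound 3 (0.45 log units; beyond the scatter). Neither tests phenyl itself. Compound 1, which also carries a ring of carbon only, gives 7000 nM, so a weak result is expected again. The expected step is an at least 1.4-fold lower number from compound 3 to compound 4 (0.15 log units; that floor lies within the scatter), an estimate set against a limit. Compound 4 is estimated at 14000 nM, within an expected range of 5000 nM to 30000 nM.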

Compound 4, half-maximal inhibitory concentration: 1000 nM
Beside the measured number, compound 4's estimate is 14-fold (1.15 log units) above it, and the stated range ends above it.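

Phenyl on the amide-type nitrogen reads better in this assay than all three earlier groups there, with an at least 20-fold lower number from compound 3 to compound 4 (1.30 log units; beyond the scatter), an at least 10-fold lower number from compound 2 to compound 4 (1.00 log units; beyond the scatter) and a 7.0-fold lower number from compound 1 to compound 4 (0.85 log units; beyond the scatter). A ring of carbon only does not settle the matter, since compound 1 carries one too and stays weaker than compound 4. Compound 3 reads as a limit, so its step is a floor: the limit of > 20000 nM in this assay, at which 1 of the 4 values shown sits.

As far as these compounds go, whether the gain follows from losing the chain carbon or from the ring itself stays open, and plain benzyl would bear on that. How cyclohexyl, or a phenyl carrying a carboxylic acid, would read is also unknown.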